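The compounds below may be only part of what the source reports. "The series", "measured", "known", "first", "only" and "open" are said of these compounds alone.

Compound 1 `O=C1C=C(Nc2ccc(I)cc2)C(=O)c2c1nc1n2[C@H]2OC[C@@H](O)[C@H]2OC1` gives 4070 nM in a functional assay on HeLa cells (Homo sapiens) for inhibition, read by sulforhodamine B assay; on this read-out lower numbers stand for stronger inhibition and higher numbers for weaker inhibition. Compound 2 `Cc1ccc(NC2=CC(=O)c3nc4n(c3C2=O)[C@H]2OC[C@@H](O)[C@H]2OC4)cc1C` gives 2690 nM. Compound 3 `O=C1C=C(NC2CCCC2)C(=O)c2c1nc1n2[C@H]2OC[C@@H](O)[C@H]2OC1` gives > 16000 nM, a limit of the assay rather than a number; among the three values shown compound 3 sits at the limit of > 16000 nM in this assay, at which 1 of the 3 values shown sits. Between the two measured numbers there is no separation: a 1.5-fold lower number from compound 1 to compound 2 (0.18 log units; within the scatter). Compound 3 falls away from both, with an at least 3.9-fold higher number from compound 1 to compound 3 (0.59 log units; beyond the scatter) and an at least 5.9-fold higher number from compound 2 to compound 3 (0.77 log units; beyond the scatter). Compound 4 `O=C1C=C(N2CCCCC2)C(=O)c2c1nc1n2[C@H]2OC[C@@H](O)[C@H]2OC1` differs from compound 3 in one place: piperidin-1-yl in place of cyclopentylamino on a double-bonded ring carbon. Within the data shown here, no measured step exchanges one such ring amine for another; the two steps reaching compound 3 only show that leaving 4-iodophenyl or 3,4-dimethylphenyl weakened inhibition. Compound 4 is therefore expected to stay weak, with a step that the limit leaves unreadable from compound 3 to compound 4, at an estimated 22000 nM in a range from 8000 nM to 60000 nM.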

Compound 4, half-maximal inhibitory concentration: > 16000 nM
Compound 4: a limit, no number (the forecaster's own chance of this, stated with the estimate: 70%); the middle value is on the limit's open side.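

Compound 4 also stands at a limit of the assay, not at a number: the limit of > 16000 nM in this assay, at which 2 of the 4 values shown sit. Weak inhibition at this double-bonded ring carbon therefore extends beyond cyclopentylamino to piperidin-1-yl, which has no hydrogen-bond donor, with an at least 5.9-fold higher number from compound 2 to compound 4 (0.77 log units; beyond the scatter) and an at least 3.9-fold higher number from compound 1 to compound 4 (0.59 log units; beyond the scatter) on leaving the two arylamino groups. The step between the two limits cannot be read, so these two groups cannot be ordered. Open, going by these compounds, is whether morpholin-4-yl or benzylamino at this carbon would give a number in this assay and how other substituents on the phenyl ring, such as methoxy or a carboxylic acid, would compare.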